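Benzyl and alkyl swaps leave solubility level

This account rests on a few compounds, and the source may have more. Where it says the series, first, only, none or still open, it means among the compounds named here.

Values in a physicochemical assay for solubility, with a stated time of 18 h, at pH 7.4; a higher number here means a more soluble compound, a lower number a less soluble compound:
Compound 1 `COc1ccc(F)cc1CNCCCNc1ccnc2cc(C3CCCCC3)ccc12` gives 4200 nM
Compound 2 `COc1ccc(F)cc1CNCCCNc1ccnc2cc(Cc3ccc(F)cc3Cl)ccc12` gives 4200 nM
Compound 3 `CCC(CC)c1ccc2c(NCCCNCc3cc(F)ccc3OC)ccnc2c1` gives 4200 nM

Compound 3 stands level with compounds 1 and 2. Compound 4 `COc1ccc(F)cc1CNCCCNc1ccnc2cc(Cc3cccc(C(F)(F)F)c3)ccc12` has 3-(trifluoromethyl)benzyl in place of pentan-3-yl on an aromatic carbon.

Three measured steps exchange the group at this place: no change at the digits printed from compound 1 to compound 2 (within the scatter), no change at the digits printed from compound 1 to compound 3 (within the scatter) and no change at the digits printed from compound 2 to compound 3 (within the scatter). Among the compounds with values here, the last is the nearest precedent, since it also exchanges a substituted benzyl group and pentan-3-yl. With all three steps of that size, no step beyond the scatter is expected in this assay. The expected outcome is no change at the digits printed from compound 3 to compound 4 (within the scatter). Compound 4 is estimated at 4200 nM, with an expected range of 2400 nM to 6500 nM.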

Compound 4, solubility: 4200 nM
Compound 4: the middle estimate sits on the measured number at the digits printed, within the range that was stated.
By their numbers in this assay, from the lowest: compounds 1, 2, 3 and 4 (each within the scatter of the next).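

In this assay, within the data shown here, this aromatic carbon also accepts 3-(trifluoromethyl)benzyl, the first group here with three fluorine atoms, since the exchange for pentan-3-yl gives no change at the digits printed from compound 3 to compound 4 (within the scatter) and nothing more. The other two exchanges read the same, with no change at the digits printed from compound 2 to compound 4 (within the scatter) for the swap of substituted phenyl groups on the benzyl carbon and no change at the digits printed from compound 1 to compound 4 (within the scatter) for the swap with cyclohexyl. All four groups at this place, with or without an aromatic ring, therefore give the same reading.

On these data alone, whether an amine or a carboxylic acid here would also read level remains open. The data shown offer no explanation for this sameness.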